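Three Compounds at the Assay Limit, a Fourth Awaited

A few compounds are considered here, and "the series" means these few. Any claim that something is new, unique, unknown or untested is made for them only; others in the source may bear on it.

Compound 1 `Cc1nnc(SCC(=O)c2ccc(Cl)cc2)n1N1C(=O)c2ccccc2C1=O`, compound 2 `C#CCSc1nnc(C)n1N1C(=O)c2ccccc2C1=O` and compound 3 `C#CCSc1nnc(-c2cc(OC)c(OC)c(OC)c2)n1N1C(=O)c2ccccc2C1=O` were tested in a functional assay on PC-3M cells (Homo sapiens) for cytotoxicity, read by MTT assay, with a stated time of 48 h; on this read-out higher numbers stand for weaker inhibition and lower numbers for stronger inhibition. In this assay compound 1 gives > 200000 nM, which is a limit of the assay, not a number. Compound 2 gives > 200000 nM, also a limit. Compound 3 gives > 200000 nM, again a limit. The change (4-chlorophenyl)carbonyl in place of ethynyl on a saturated chain carbon bound to a sulfur therefore yields a step that the two limits leave unreadable from compound 2 to compound 1, unreadable because of the limit of > 200000 nM in this assay, at which 3 of the 3 values shown sit. How the cores of compound 2 and compound 3 differ is not broken down here.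

Compound 4 `COc1cc(-c2nnc(SCC(=O)c3ccc(Cl)cc3)n2N2C(=O)c3ccccc3C2=O)cc(OC)c1OC` is not yet measured. It differs from compound 3 by (4-chlorophenyl)carbonyl in place of ethynyl on a saturated chain carbon bound to a sulfur, the same change seen from compound 2 to compound 1. The step is expected to be a number no higher from compound 3 to compound 4 (the limit leaves the size open). This expectation rests on compound 3, whose value > 200000 nM is a limit. Compound 4 is thus estimated at 200000 nM, between 60000 nM and 400000 nM.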

Compound 4, half-maximal inhibitory concentration: 20700 nM
Estimate against measurement, compound 4: 9.7-fold (0.99 log units) above, and the stated range ends above it.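

In this assay, putting (4-chlorophenyl)carbonyl in place of ethynyl gives an at least 9.6-fold lower number from compound 3 to compound 4 (0.98 log units; beyond the scatter) on the trimethoxyphenyl core, and this size is only a floor, since compound 3 stands at a limit and not at a number. The same change from compound 2 to compound 1 cannot be read, so carrying it from one core to another is not shown, because both ends sit at a limit: the limit of > 200000 nM in this assay, at which 3 of the 4 values shown sit. With the (4-chlorophenyl)carbonyl group kept, 3,4,5-trimethoxyphenyl in place of methyl gives an at least 9.6-fold lower number from compound 1 to compound 4 (0.98 log units; beyond the scatter) and this too starts from a limit, that of compound 1.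

Open, on these data alone, is whether an amine or a carboxylic acid on that chain carbon would lower the number further. As far as these compounds go, a longer chain there remains equally open.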